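The source may hold more compounds than are shown below. What is called first, only, known or untested is meant among the compounds shown, and "the series" means these compounds.

Of the compounds shown here, two have been measured so far, both built on the same core. Compound 1 `O=c1ccc(-c2ccc3cn[nH]c3c2)cn1Cc1ccccc1` carries a plain benzyl arm, and in an assay for inhibition of MAP kinase-interacting serine/threonine-protein kinase 1 (Homo sapiens), read by luminescence and ADP-Glo, with a stated time of 2 h (a higher number here means a weaker inhibitor, a lower number a stronger inhibitor), compound 1 gives 315 nM. Compound 2 `O=c1ccc(-c2ccc3cn[nH]c3c2)cn1Cc1cccc(Cl)c1` differs only by a chloro group on that benzyl ring, and in this assay compound 2 gives 37 nM. The step of an 8.5-fold lower number from compound 1 to compound 2 (0.93 log units; beyond the scatter) shows that this one substituent made a clear difference. Compound 2 therefore stands with the lowest number of the two and is the stronger inhibitor.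

Compound 3 `O=c1ccc(-c2ccc3cn[nH]c3c2)cn1Cc1cccc(F)c1` is the next variation, differing from compound 2 in a single place: fluoro in place of chloro on an aromatic carbon. Within the data shown here, only one measured step bears on this, an 8.5-fold lower number from compound 1 to compound 2 (0.93 log units; beyond the scatter), which says how much the chloro group was worth against bare hydrogen. Among the measured compounds shown here, no measurement yet shows where fluoro falls between those two. Compound 3 is expected to keep part of that gain without keeping all of it, so the expected step is a 2.7-fold higher number from compound 2 to compound 3 (0.43 log units; beyond the scatter) toward a weaker inhibitor. For compound 3 the estimate in this assay is 100 nM, within a range of 40 nM to 250 nM.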

Compound 3, half-maximal inhibitory concentration: 74 nM
For compound 3 the middle estimate is 1.4-fold (0.13 log units) above the measured one; the measured number falls inside the stated range.
By their numbers in this assay, from the lowest: compounds 2 and 3 (each within the scatter of the next); then compound 1.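

Going from 3-chlorobenzyl to 3-fluorobenzyl in this assay gives a 2.0-fold higher number from compound 2 to compound 3 (0.30 log units; within the scatter), so at this place on the benzyl ring, the two halogens cannot be told apart in these data. The gain over the plain benzyl arm is therefore not confined to chloro, since a 4.3-fold lower number from compound 1 to compound 3 (0.63 log units; beyond the scatter) is a step that lies clearly beyond the scatter, and what mattered here was replacing hydrogen with either of these two halogens rather than the choice between them. Nothing measured on these compounds explains that gain over hydrogen, so the data record the size of the effect but give no reason for it.

From the compounds shown here alone, it remains open whether the gain depends on having a halogen at all, or whether a methyl, methoxy, trifluoromethyl, nitrile or amine group at this same place would match it, fall back toward the plain benzyl arm or go further. The compounds shown also leave open whether chloro or fluoro would give a similar result at any other place on the benzyl ring, since both sit at the same place here.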